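The source may hold more compounds than are shown below. What is called first, only, known or untested is meant among the compounds shown, and "the series" means these compounds.

For the measured compounds named here, in a functional assay on T47D cells (Homo sapiens) for antiproliferative activity, with a stated time of 48 h (a lower number here means a stronger inhibitor of growth, a higher number a weaker inhibitor of growth), compound 2 `Cc1cc(O)c(C2=NN(c3ccc(S(N)(=O)=O)cc3)C(c3ccccc3Cl)C2)cc1Cl` gives 2810 nM, the lower of the two numbers known, while compound 1 `Cc1cc(O)c(C2=NN(c3ccc(S(N)(=O)=O)cc3)C(c3ccccc3O)C2)cc1Cl` gives 3180 nM; the single measured step, a 1.1-fold lower number from compound 1 to compound 2 (0.05 log units; within the scatter), lies within the scatter. Compound 3 `Cc1cc(O)c(C2=NN(c3ccc(S(N)(=O)=O)cc3)C(/C=C/c3ccccc3)C2)cc1Cl` differs from compound 2 by 2-phenylethenyl in place of 2-chlorophenyl on a saturated ring carbon. Going by the values given here, no measured step touches this kind of change; the one step known concerns another part of the molecule and was small. The expected step of a 1.1-fold higher number from compound 2 to compound 3 (0.03 log units; within the scatter) is therefore uncertain and may well stay within the scatter. Compound 3 is estimated at 3000 nM, in a range from 900 nM to 10000 nM.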

Compound 3, concentration for 50% growth inhibition: 3380 nM
Estimate against measurement, compound 3: 1.1-fold (0.05 log units) below; the measured number falls inside the stated range.
By their numbers in this assay, from the lowest: compounds 2, 1 and 3 (each within the scatter of the next).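

In this assay, putting 2-phenylethenyl on the saturated ring carbon in place of 2-chlorophenyl gives a 1.2-fold higher number from compound 2 to compound 3 (0.08 log units; within the scatter), and putting it there in place of 2-hydroxyphenyl gives a 1.1-fold higher number from compound 1 to compound 3 (0.03 log units; within the scatter). Across these three compounds, then, this position accepts a group with a double bond outside aromatic rings with no change beyond the scatter. No supporting data are available to explain this result.

All three groups at this carbon contain a six-membered aromatic ring of carbon only. On these data alone, what an amine, a carboxylic acid or a longer saturated chain would do at this position remains open.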